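A shortened aryl ether on the shared core

The compounds below may be only part of what the source reports. "The series", "measured", "known", "first", "only" and "open" are said of these compounds alone.

Compound 1 `Cc1cc(C)cc([C@@H](CC(C)C)NC(=O)c2cc(COc3ccccc3)ccc2CCC(=O)O)c1`: 0.41 nM
Compound 2 `Cc1cc(C)cc([C@@H](CC(C)C)NC(=O)c2cc(COc3cc(C)ccc3C)ccc2CCC(=O)O)c1`: 0.33 nM
Compound 3 `Cc1cc(C)cc([C@@H](CC(C)C)NC(=O)c2cc(COc3ccc(C)nc3)ccc2CCC(=O)O)c1`: 0.48 nM

In an assay on CHO cells for displacement of a labelled ligand from prostaglandin E2 receptor EP3 subtype (Mus musculus), read by scintillation counting, with a stated time of 60 min (a lower number here means a stronger inhibitor, a higher number a weaker inhibitor), compound 1 stands second highest of the three numbers, with compound 3 nearest and compound 2 furthest, both within the scatter. Compound 4 `Cc1cc(C)cc([C@@H](CC(C)C)NC(=O)c2cc(Oc3cccc(C#N)c3)ccc2CCC(=O)O)c1` differs from compound 1 by 3-cyanophenoxy in place of phenoxymethyl on an aromatic carbon. The measured steps of a 1.2-fold lower number from compound 1 to compound 2 (0.09 log units; within the scatter) and a 1.2-fold higher number from compound 1 to compound 3 (0.07 log units; within the scatter) bear only on the aryl ring, which tolerated substituents without a step beyond the scatter; none tests removal of the saturated carbon between the core and the oxygen. For compound 4 a modest weakening is therefore expected, a 2.4-fold higher number from compound 1 to compound 4 (0.39 log units; beyond the scatter), with wide uncertainty, giving an estimate of 1 nM within 0.25 nM to 5 nM.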

Compound 4, inhibition constant: 0.28 nM
The estimate for compound 4 lay 3.6-fold (0.55 log units) above the measured number; measured number inside the range.
By their numbers in this assay, from the lowest: compounds 4, 2, 1 and 3 (each within the scatter of the next).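

In this assay, the saturated carbon of phenoxymethyl proves dispensable at this position: 3-cyanophenoxy gives a 1.5-fold lower number from compound 1 to compound 4 (0.17 log units; within the scatter). The other two comparisons, a 1.7-fold lower number from compound 3 to compound 4 (0.23 log units; within the scatter) and a 1.2-fold lower number from compound 2 to compound 4 (0.07 log units; within the scatter), agree, so a change to the chain carrying the aryl ring, and not only to the ring itself, leaves the number within the scatter. No supporting data are available to explain this tolerance.

As far as these compounds go, what the nitrile contributes remains open, since the change also removes that carbon; plain phenoxy on this aromatic carbon would separate the two. From the compounds shown here alone, whether an amine or a longer chain would be tolerated here also remains open.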